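The source may hold more compounds than are shown below. What is called first, only, known or untested is meant among the compounds shown, and "the series" means these compounds.

Working notes on the series in an ADME assay on the whole organism (plasma) for pharmacokinetics, with Rattus norvegicus as the target, at a dose of 10 mg/kg by the oral route; on this read-out higher numbers stand for higher exposure at the dose given and lower numbers for lower exposure. Of the compounds shown here, two have numbers so far. Compound 1, `CC[C@@H](Nc1c(Nc2cccc(C(=O)N(C)C(C)C)c2O)c(=O)c1=O)c1ccccc1`, gives 590 ng.h/mL in this assay. Compound 2, `CC[C@@H](Nc1c(Nc2cc(Br)cc(C(=O)N(C)C)c2O)c(=O)c1=O)c1cccs1`, gives 670 ng.h/mL in this assay. For the measured compounds named here, compound 1 holds the lower of the two numbers, but the gap to compound 2 is within the scatter, so the two cannot be ordered; compound 2 also differs from compound 1 in more than one place, so no single step between them is defined.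

Compound 3, `CC[C@@H](Nc1c(Nc2cccc(C(=O)N3CC[C@H](CO)C3)c2O)c(=O)c1=O)c1ccccc1`, has not yet been measured in this assay. It differs from compound 1 in one place: 3-(hydroxymethyl)pyrrolidin-1-yl in place of isopropyl(methyl)amino on a carbonyl carbon

Going by the values given here, no measured pair shows the effect of this change, so there is nothing to lean on beyond the numbers of compound 1 and compound 2. The step from compound 1 to compound 3 is expected to be modest, if anything downward, and may well stay within the scatter: a 1.7-fold lower number from compound 1 to compound 3 (0.23 log units; within the scatter). On that basis compound 3 is estimated at 350 ng.h/mL in this assay, with a range of 120 ng.h/mL to 1000 ng.h/mL.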

Compound 3, area under the concentration-time curve: 198 ng.h/mL
Estimate against measurement, compound 3: 1.8-fold (0.25 log units) above; the range from low to high includes it.
By their numbers in this assay, from the lowest: compound 3; then compounds 1 and 2 (each within the scatter of the next).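

On a carbonyl carbon of the shared core, the series now has its first single-place comparison: in this assay, 3-(hydroxymethyl)pyrrolidin-1-yl in place of isopropyl(methyl)amino gives a 3.0-fold lower number from compound 1 to compound 3 (0.47 log units; beyond the scatter), so exposure at this position responds to the group carried there. The entering group differs from the leaving one in several counted features at once, bringing a five-membered non-aromatic ring, a hydrogen-bond donor, a hydrogen-bond acceptor and a defined stereocentre, so this one step cannot assign the lower number to any one of them. No measurement bearing on the reason for the lower number is available.

Going by these compounds, it remains open whether the lower number goes with the ring or with the hydroxymethyl, a question that a plain pyrrolidin-1-yl or a 3-(methoxymethyl)pyrrolidin-1-yl on the same carbonyl carbon would address. Also open, on these data alone, are the effect of the opposite configuration at the stereocentre and whether a step of this size would carry over to the different substitution pattern of compound 2.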